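A few compounds are considered here, and "the series" means these few. Any claim that something is new, unique, unknown or untested is made for them only; others in the source may bear on it.

Of the compounds shown here, two built on one shared core have been tested in a functional assay (muscle tissue) with Cavia porcellus as the target; on this read-out lower numbers stand for an effect already at smaller amounts and higher numbers for an effect only at larger amounts of compound. Compound 1 `COC(=O)C1=C(C)N=C(C)/C(=C(\O)OC)C1c1ccccc1C#N` gives 15.9 nM, while compound 2 `COC(=O)C1=C(C)N=C(C)/C(=C(\O)OC)C1c1cccc(OC(C)=O)c1` gives 6030 nM, the higher of the two numbers by a wide margin. Compound 3 `COC(=O)C1=C(C)N=C(C)/C(=C(\O)OC)C1c1cccc(F)c1` is the next one to be measured. It differs from compound 2 in one place: fluoro in place of acetoxy on an aromatic carbon. Within the data shown here, no measured pair shows this particular change, so the step has to be estimated. A clear fall is expected, a 60-fold lower number from compound 2 to compound 3 (1.78 log units; beyond the scatter). This expectation rests on compound 1, which reaches 15.9 nM on the same core. Compound 3 is therefore expected to give 100 nM, within a range of 15 nM to 800 nM.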

Compound 3, half-maximal effective concentration: 20.9 nM
The estimate for compound 3 lay 4.8-fold (0.68 log units) above the measured number, within the range that was stated.
By their numbers in this assay, from the lowest: compounds 1 and 3 (each within the scatter of the next); then compound 2.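

In this assay, the group on this aromatic carbon matters greatly: fluoro in place of acetoxy gives a 290-fold lower number from compound 2 to compound 3 (2.46 log units; beyond the scatter). Putting 3-fluorophenyl in place of 2-cyanophenyl on the saturated ring carbon gives a 1.3-fold higher number from compound 1 to compound 3 (0.12 log units; within the scatter), so these two differently substituted rings read alike on the shared core. Nothing available explains why acetoxy and fluoro differ so sharply. As far as these compounds go, how an amine or a hydroxyl group would read at this same place remains open, as does whether fluoro would hold its number elsewhere on the aromatic ring.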